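Shortening the Side Chain of Compound 1

The compounds below may be only part of what the source reports. "The series", "measured", "known", "first", "only" and "open" are said of these compounds alone.

In a functional assay on V79 cells (Cricetulus griseus) for cytotoxicity, read by colony formation (a higher number here means a weaker inhibitor, a lower number a stronger inhibitor), compound 1 `CCNCC1CCN(c2c(F)cc3c(=O)c(C(=O)O)cn(CC)c3c2F)C1` gives 160 ug/mL and compound 3 `CCNCC1CCN(c2cc3c(cc2F)c(=O)c(C(=O)O)cn3CC)C1` gives 310 ug/mL, values within the scatter of each other. Compound 2 `CCNCC1CCN(c2c(F)cc3c(=O)c(C(=O)O)cn(NC)c3c2F)C1` is reported only as a limit, > 500 ug/mL. Compound 4 `CCn1cc(C(=O)O)c(=O)c2cc(F)c(N3CCC(N)C3)c(F)c21` carries amino in place of (ethylamino)methyl on a saturated ring carbon. Neither measured step touches that place: methylamino in place of ethyl gave an at least 3.1-fold higher number from compound 1 to compound 2 (0.49 log units; beyond the scatter), and hydrogen in place of fluoro gave a 1.9-fold higher number from compound 1 to compound 3 (0.29 log units; within the scatter). These steps offer only a rough guide to size in this assay and give no direction for this change. The expected outcome is a 1.8-fold lower number from compound 1 to compound 4 (0.25 log units; within the scatter), a tentative lean toward a lower number. Compound 4 is estimated at 90 ug/mL, with an expected range from 25 ug/mL to 300 ug/mL.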

Compound 4, half-maximal inhibitory concentration: 300 ug/mL
Compound 4: middle estimate off by 3.3-fold (0.52 log units), on the low side, within the range that was stated.
By their numbers in this assay, from the lowest: compounds 1, 4 and 3 (each within the scatter of the next). At a limit, above all of these: compound 2.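

In this assay, the exchange of (ethylamino)methyl for amino gives a 1.9-fold higher number from compound 1 to compound 4 (0.27 log units; within the scatter) and is the first step shown at this saturated ring carbon. Compound 1 and compound 4 therefore cannot be told apart in this assay, even though the side chain of compound 4 is much shorter, with amino in place of the larger group. Nothing among the available data explains this result.

As far as these compounds go, whether aminomethyl or a longer chain on this carbon would also stay within the scatter remains open. From the compounds shown here alone, it is also open whether amino would read the same on a core carrying hydrogen in place of fluoro.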